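Swapping an imidazole amide for a pyridine amide

This account rests on a few compounds, and the source may have more. Where it says the series, first, only, none or still open, it means among the compounds named here.

Of the compounds shown here, three sharing one core have been measured in a functional assay on A549 cells (Homo sapiens) for antiproliferative activity, read by sulforhodamine B assay, with a stated time of 3 days; a higher number here means a weaker inhibitor of growth, a lower number a stronger inhibitor of growth. Compound 1 `Cn1ccnc1NC(=O)c1cccc(Nc2ncc(F)c(Nc3ccc(F)cc3)n2)c1` gives 10100 nM in this assay. Compound 2 `COc1ccc(N2CCN(C)CC2)cc1Nc1ncc(F)c(Nc2ccc(F)cc2)n1` gives 1130 nM in this assay, and compound 3 `O=C(Nc1cccc(Nc2ncc(F)c(Nc3ccc(F)cc3)n2)c1)c1ccccc1` gives 37800 nM in this assay. Compound 1 therefore stands second highest of the three numbers, with compound 3 nearest and compound 2 furthest from it.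

Compound 4 `O=C(Nc1ccccn1)c1cccc(Nc2ncc(F)c(Nc3ccc(F)cc3)n2)c1` is the unmeasured case. It differs from compound 1 in one place: pyridin-2-yl in place of 1-methyl-1H-imidazol-2-yl on an amide-type nitrogen.

Going by the values given here, only one measured step touches the amide end of the molecule: a 3.7-fold higher number from compound 1 to compound 3 (0.57 log units; beyond the scatter). That change reversed the amide and removed the heteroaromatic ring altogether, so it bears on the present step only loosely. Compound 4 keeps the amide direction and keeps an aromatic ring on the amide nitrogen, so a step of modest size at most is expected, with no clear direction beyond the scatter. The number for compound 4 in this assay is estimated at 8000 nM, with a range from 2500 nM to 25000 nM, which means an expected step of a 1.3-fold lower number from compound 1 to compound 4 (0.10 log units; within the scatter).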

Compound 4, concentration for 50% growth inhibition: 15300 nM
Estimate against measurement, compound 4: 1.9-fold (0.28 log units) below; the range from low to high includes it.
By their numbers in this assay, from the lowest: compound 2; then compounds 1 and 4 (each within the scatter of the next); then compound 3.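

In this assay, the step of a 1.5-fold higher number from compound 1 to compound 4 (0.18 log units; within the scatter) shows that this exchange of one aromatic ring for another on the amide-type nitrogen gives a difference too small to read. The step of a 2.5-fold lower number from compound 3 to compound 4 (0.39 log units; beyond the scatter) lies beyond the scatter, but it changes both the amide direction and the ring, so it cannot show which of the two matters. No measurement at hand offers a reason for either step.

The compounds shown leave open what a plain phenyl ring on the same amide nitrogen would give, which would separate the ring from the amide direction. They also leave open whether a non-aromatic group there, such as a cyclohexyl ring or a short alkyl chain, would fall in the same range.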